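Shortening the alkyl group on compound 1's aryl ring

This account rests on a few compounds, and the source may have more. Where it says the series, first, only, none or still open, it means among the compounds named here.

Measured compounds:
- compound 1, `CC(C)c1ccc(-c2nc(CN3CCCC3)nn2C)cc1`: 1000 nM
- compound 2, `Cn1nc(CN2CCCC2)nc1-c1cccc(C2(C(F)(F)F)CC2)c1`: > 1000 nM
- compound 3, `CC(C)(C)c1ccc(-c2nc(CN3CCCC3)nn2C2CC2)cc1`: 750 nM

In an assay on membranes from Jurkat cells for displacement of a labelled ligand from Sigma intracellular receptor 2 (Homo sapiens), read by scintillation counting, with a stated time of 1 h (a lower number here means a stronger inhibitor, a higher number a weaker inhibitor), compound 1 gives 1000 nM. This is the higher of the two numbers reported; the nearest is compound 3, which in this assay gives 750 nM, and the gap between the two lies within the scatter of the measurement, so no order between them can be claimed. Compound 2 in this assay is reported only as a limit, > 1000 nM, and not as a number (the limit of > 1000 nM in this assay, at which 1 of the 3 values shown sits).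

The step from compound 1 to the unmeasured compound 4, `Cc1ccc(-c2nc(CN3CCCC3)nn2C)cc1`, is a single change: methyl in place of isopropyl on an aromatic carbon. Going by the values given here, no step between measured compounds of this kind exists here, so its size is not known from the data. The account expects a modest rise in the number, of a size near the edge of the scatter, and compound 4 is estimated at 1600 nM, between 600 nM and 4500 nM, which as an expected step means a 1.6-fold higher number from compound 1 to compound 4 (0.20 log units; within the scatter).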

Compound 4, inhibition constant: > 1000 nM
Compound 4: only a limit was reported; the forecaster's own chance of this, stated with the estimate: 50%; the middle value does not contradict the limit.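

In this assay compound 4 gives > 1000 nM, which is a limit and not a number. Going by these compounds alone, this is the first single change at this aromatic carbon, and methyl in place of isopropyl brings a number no lower from compound 1 to compound 4 (the limit leaves the size open) though the size of the step cannot be read. Compound 4 thus joins compound 2 in being reported only as a limit, so fewer of the compounds shown can be ranked by number: the limit of > 1000 nM in this assay, at which 2 of the 4 values shown sit.

The compounds shown leave open how far the true value of compound 4 lies from that of compound 1. They also leave open whether an ethyl group, a methoxy group or a chlorine atom on this aromatic carbon would give a readable number.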